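The source may hold more compounds than are shown below. What is called first, only, known or untested is meant among the compounds shown, and "the series" means these compounds.

Compound 2 `CC(C)c1onc(-c2c(Cl)cccc2Cl)c1COc1ccc(N(C)C(=O)c2cccc(C(=O)O)c2)c(C(F)(F)F)n1` gives 537 nM in a functional assay on HEK293 cells for agonist activity at Bile acid receptor (Homo sapiens), read by a luciferase reporter (on this read-out higher numbers stand for an effect only at larger amounts of compound and lower numbers for an effect already at smaller amounts), and so stands highest of the three measured numbers. Compound 1 `CC(C)c1onc(-c2c(Cl)cccc2Cl)c1COc1ccc(N(C)C(=O)c2ccc(C(=O)O)cc2)c(C(F)(F)F)n1` gives 208 nM in this assay, and compound 3 `CC(C)c1onc(-c2c(Cl)cccc2Cl)c1COc1ccc(NCc2ccc(C(=O)O)cc2)c(C(F)(F)F)n1` gives 101 nM. Among the compounds with values here, the one measured single-point step is a 2.6-fold higher number from compound 1 to compound 2 (0.41 log units; beyond the scatter), which brings the 3-carboxyphenyl to the 4-carboxyphenyl and leaves the rest untouched. No step is listed between compound 1 and compound 3; their two values show that the amide with a methyl on the nitrogen and the secondary amine with a benzyl sit within a modest distance of each other, compound 3 giving the lower number.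

The change to compound 4 `CC(C)c1onc(-c2c(Cl)cccc2Cl)c1COc1ccc(N(C)Cc2ccc(CCC(=O)O)cc2)c(C(F)(F)F)n1` is 4-(2-carboxyethyl)benzyl in place of (3-carboxyphenyl)carbonyl on a nitrogen on an aromatic ring. It moves the acid back toward the position of compound 1 and compound 3, replaces the carbonyl by a saturated chain carbon, and extends the acid by two carbons beyond the ring. Within the data shown here, the first part bears on the step from compound 1 to compound 2 and would be expected to reverse it; the other parts have no measured counterpart here.

On that basis compound 4 is expected to give 200 nM in this assay, in a range from 50 nM to 800 nM, which would be a step of a 2.7-fold lower number from compound 2 to compound 4 (0.43 log units; beyond the scatter). The reversal rests on compound 1, which gives 208 nM, and on compound 3, which gives 101 nM. Both of those numbers lie below that of compound 2, and the chain extension widens the range.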

Compound 4, half-maximal effective concentration: 16 nM
For compound 4 the middle estimate is 13-fold (1.10 log units) above the measured one, outside the stated range (below it).
By their numbers in this assay, from the lowest: compound 4; then compound 3; then compound 1; then compound 2.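

On the nitrogen on an aromatic ring, 4-(2-carboxyethyl)benzyl in place of (3-carboxyphenyl)carbonyl gives a 34-fold lower number from compound 2 to compound 4 (1.53 log units; beyond the scatter) in this assay, and in place of (4-carboxyphenyl)carbonyl it gives a 13-fold lower number from compound 1 to compound 4 (1.11 log units; beyond the scatter) on the same read-out. Within the data shown here, both steps are large and exceed a 2.6-fold higher number from compound 1 to compound 2 (0.41 log units; beyond the scatter) as the only earlier step, so this position allows much more movement in the number than the swap between the two carboxyphenyl groups showed. The entering group differs in its linker and in its acid chain at once, and nothing at hand accounts for the size of these steps.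

From the compounds shown here alone, whether the lower number follows the loss of the carbonyl, the 2-carboxyethyl chain or both remains open. A 4-carboxybenzyl group on the same nitrogen would separate the two, and a 3-carboxypropyl group would show whether a longer chain continues the trend.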